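Capping the carboxy of compound 2 with an oxadiazole

The compounds below may be only part of what the source reports. "The series", "measured", "known", "first", "only" and "open" are said of these compounds alone.

Measured in a functional assay on HT-29 cells (Homo sapiens); a lower number here means a stronger inhibitor, a higher number a weaker inhibitor:
Compound 1 `COC(=O)c1nn([C@@H]2O[C@H](CO)[C@@H](O)[C@H]2O)cc1I`: 2800 nM
Compound 2 `O=C(O)c1nn([C@@H]2O[C@H](CO)[C@@H](O)[C@H]2O)cc1I`: > 300000 nM

Compound 2 stands at the limit of > 300000 nM in this assay, at which 1 of the 2 values shown sits, and this is a limit, not a number. Compound 3 `Cc1noc(-c2nn([C@@H]3O[C@H](CO)[C@@H](O)[C@H]3O)cc2I)n1` is not yet measured. The change that leads to it is 3-methyl-1,2,4-oxadiazol-5-yl in place of carboxy on an aromatic carbon and, in words, 3-methyl-1,2,4-oxadiazol-5-yl takes the place of carboxy on an aromatic carbon.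

Within the data shown here, only one measured step bears on this change. It is an at least 100-fold higher number from compound 1 to compound 2 (2.02 log units; beyond the scatter) and it is large and beyond the scatter. There, hydrogen replaces methyl on an oxygen next to a carbonyl group, so the free carboxy appears in compound 2 and measurable inhibition is lost. Compound 3, like compound 1, has no free carboxy, so its number is expected to fall back towards that of compound 1, which stands at 2800 nM. That makes a large step to a lower number the expectation in this assay, though it rests on a single pair and on a different group.

The expected change is an at least 50-fold lower number from compound 2 to compound 3 (1.69 log units; beyond the scatter) in size. For compound 3 the estimate is 6000 nM, with an expected range from 1000 nM to 40000 nM.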

Compound 3, half-maximal inhibitory concentration: 4800 nM
Estimate against measurement, compound 3: 1.3-fold (0.10 log units) above; low and high end bracket the measured number.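

In this assay, 3-methyl-1,2,4-oxadiazol-5-yl in place of carboxy on this aromatic carbon restores measurable inhibition, with an at least 62-fold lower number from compound 2 to compound 3 (1.79 log units; beyond the scatter). The starting point of that step is a limit and not a number, and it belongs to compound 2: the limit of > 300000 nM in this assay, at which 1 of the 3 values shown sits. Against methoxycarbonyl the new ring shows no readable difference, with a 1.7-fold higher number from compound 1 to compound 3 (0.23 log units; within the scatter), so among these three compounds inhibition at this level is not tied to methoxycarbonyl alone, and two quite different groups serve equally well here while only the carboxy of compound 2 stands apart.

The compounds shown leave open whether a carboxamide or a small amine on this carbon would behave like compound 1 or like compound 2, and so which feature of the carboxy goes with the loss of inhibition. They also leave open whether a longer chain in place of the methyl on the oxadiazole ring could reach a clearly lower number than compound 1 and compound 3 give.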